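The source may report more compounds than this note shows. Statements on the series, on what has been measured and on what is new or still open speak of the compounds shown alone.

Compounds measured in an ADME assay on RAW264.7 cells (Mus musculus) for cytotoxicity, read by MTT assay, with a stated time of 24 h; a higher number here means that more compound is tolerated, a lower number that less compound is tolerated:
- compound 1 `CC/C=C\C[C@H]1C(=O)C=C[C@H]1CC(=O)OCCCCC`: 37 uM
- compound 2 `CC/C=C\C[C@H]1C(=O)C=C[C@H]1CC(=O)OCCO`: 161 uM

Of these two, compound 2 has the higher number at 161 uM, so more of it is tolerated than of compound 1 at 37 uM.

Compound 3 `CC/C=C\C[C@H]1C(=O)C=C[C@H]1CC(=O)OCCOC` has not yet been measured in this assay. It differs from compound 2 by a single change: methyl in place of hydrogen on an oxygen on a saturated carbon. This is methyl in place of hydrogen on an oxygen on a saturated carbon, which turns 2-hydroxyethyl into 2-methoxyethyl.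

For the measured compounds named here, no measured step shows this exact change, so the only guide is a 4.4-fold higher number from compound 1 to compound 2 (0.64 log units; beyond the scatter), which came with hydroxy in place of propyl. Compound 3 keeps the oxygen of compound 2 but loses its hydroxy, so structurally it falls between compound 1 and compound 2. Two compounds cannot establish a pattern, so this is a weak guide.

A small downward move is expected, one that may not clear the usual scatter: a 1.6-fold lower number from compound 2 to compound 3 (0.21 log units; within the scatter). The estimate for compound 3 is 100 uM, with an expected range from 50 uM to 190 uM.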

Compound 3, half-maximal toxic concentration: 160 uM
Estimate against measurement, compound 3: 1.6-fold (0.20 log units) below; low and high end bracket the measured number.
By their numbers in this assay, from the lowest: compound 1; then compounds 3 and 2 (each within the scatter of the next).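

In this assay, turning 2-hydroxyethyl into 2-methoxyethyl gives a 1.0-fold lower number from compound 2 to compound 3 (0.00 log units; within the scatter), so at this position a methyl can replace the hydrogen on the oxygen with no visible change in the number. Methoxy in place of propyl gives a 4.3-fold higher number from compound 1 to compound 3 (0.64 log units; beyond the scatter), a step of the same size as a 4.4-fold higher number from compound 1 to compound 2 (0.64 log units; beyond the scatter), which shows that the rise seen with hydroxy does not depend on that hydrogen being present. Among these three compounds, the two with an oxygen at this place stand together and apart from compound 1, but no accompanying measurement explains this result.

As far as these compounds go, it remains open whether the rise is specific to an oxygen at this place, since an amine or a carboxylic acid there could fit with the two oxygen compounds or fall apart from them. From the compounds shown here alone, it is also open how far the methyl can grow, as an ethoxy group or a longer chain on the same oxygen could keep the number where it is or bring it back towards that of compound 1.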